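The source may report more compounds than this note shows. Statements on the series, on what has been measured and on what is new or still open speak of the compounds shown alone.

Working notes on the series, read in a functional assay on KYSE-410 cells (Homo sapiens) for antiproliferative activity, read by MTT assay, with a stated time of 72 h; on this read-out lower numbers stand for stronger inhibition and higher numbers for weaker inhibition. The shared core with one varied group is shown by compound 1 `O=C(Nc1cccc(F)c1)c1cc(=O)[nH]c2cc(-c3ccccc3)ccc12`. Compound 1 gives > 20000 nM, which is a limit of the assay and not a number. For the measured compounds named here, compound 2 `O=C(Nc1cccc(F)c1)c1cc(=O)[nH]c2cc(-c3ccsc3)ccc12` gives 4300 nM, the only true number so far. Compound 3 `O=C(Nc1cccc(F)c1)c1cc(=O)[nH]c2cc(-c3ccncc3)ccc12` gives > 20000 nM, which is also a limit. Most of the series therefore sits at the limit of > 20000 nM in this assay, at which 2 of the 3 values shown sit, and compound 3 has no exact position.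

Compound 4 `O=C(Nc1cccc(F)c1)c1cc(=O)[nH]c2cc(C3=CCOCC3)ccc12` changes compound 3 as follows: a group of 6 heavy atoms (5 carbon, 1 oxygen; one six-membered non-aromatic ring with 1 hetero atom) in place of a group of 6 heavy atoms (5 carbon, 1 nitrogen; one six-membered aromatic ring with 1 hetero atom), on an aromatic carbon. Going by the values given here, three steps bear on this change. The readable ones are an at least 4.6-fold lower number from compound 1 to compound 2 (0.66 log units; beyond the scatter) and an at least 4.6-fold higher number from compound 2 to compound 3 (0.66 log units; beyond the scatter), both of which involve thiophen-3-yl. The third is a step that the two limits leave unreadable from compound 1 to compound 3. None of them replaces an aromatic ring with a non-aromatic one, so the transfer to compound 4 is loose. The expectation is a modest move to a lower number in this assay, no larger than the gap seen with compound 2 at 4300 nM. A result at the limit remains quite possible. The expected step is an at least 1.6-fold lower number from compound 3 to compound 4 (0.22 log units; that floor lies within the scatter). The estimate for compound 4 is 12000 nM, with an expected range of 4000 nM to 30000 nM.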

Compound 4, half-maximal inhibitory concentration: 12100 nM
Compound 4: middle estimate off by 1.0-fold (0.00 log units), on the low side; the measured number falls inside the stated range.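

The non-aromatic ring with its double bond outside aromatic rings gives a true number in this assay, so on this aromatic carbon a readable value does not depend on an aromatic group: the steps are an at least 1.6-fold lower number from compound 3 to compound 4 (0.21 log units; that floor lies within the scatter) and an at least 1.6-fold lower number from compound 1 to compound 4 (0.21 log units; that floor lies within the scatter), and neither floor establishes a gain beyond the usual variation. The same replacement does not match thiophen-3-yl, with a 2.8-fold higher number from compound 2 to compound 4 (0.45 log units; beyond the scatter), which leaves compound 2 the strongest of the four compounds, while compound 4 has the second true number in the series. The two six-membered aromatic groups, phenyl and pyridin-4-yl, remain unresolved against each other, and the series still has this ceiling: the limit of > 20000 nM in this assay, at which 2 of the 4 values shown sit.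

The compounds shown leave open whether the double bond matters, which tetrahydropyran-4-yl would address, and whether the ring oxygen matters, which a piperidin-4-yl group carrying an amine would address. They also leave open whether the lower number with thiophen-3-yl extends to another five-membered group such as furan-3-yl, or persists when the rest of the shared core changes.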